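This account rests on a few compounds, and the source may have more. Where it says the series, first, only, none or still open, it means among the compounds named here.

Measured compounds:
- compound 1 `FC(F)Oc1ccccc1C1Cc2nccn2C1`: 22 mL.min-1.g-1
- compound 2 `COc1ccccc1C1CCc2nc[nH]c2C1`: "not determined" (no result reported)
- compound 3 `COc1ccc(C2Cc3nccn3C2)cc1`: 30 mL.min-1.g-1

The series is followed in an in vitro ADME assay on microsomes from liver (Homo sapiens) for metabolic stability; a higher number here means faster removal of the compound, a lower number slower removal. Compound 1 gives 22 mL.min-1.g-1 and compound 3 gives 30 mL.min-1.g-1 in this assay; the two values lie within the usual scatter of one another, so no order can be read between them. For the measured compounds named here, compound 2 carries no number in this assay, and no step between measured compounds is available for this series, so nothing can be said about what a change on the aromatic ring does to the read-out here.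

Compound 4 `Clc1ccccc1C1CCc2nc[nH]c2C1` differs from compound 2 by chloro in place of methoxy on an aromatic carbon. Where compound 2 stands is unknown, so the step from compound 2 to compound 4 in this assay cannot be sized; no direction beyond the scatter is assumed for it. Compound 4 is therefore placed on the range that compounds 1 and 3 span. Compound 4 is expected to give about 22 mL.min-1.g-1 in this assay, with a range from 8 mL.min-1.g-1 to 55 mL.min-1.g-1.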

Compound 4, intrinsic clearance in microsomes: 10 mL.min-1.g-1
Estimate against measurement, compound 4: 2.2-fold (0.34 log units) above; the measured number falls inside the stated range.
By their numbers in this assay, from the lowest: compound 4; then compounds 1 and 3 (each within the scatter of the next).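

In this assay compound 2 has no single number, so no new step can be read from compound 4. The compounds shown leave open what chloro in place of methoxy does to the read-out on this core. No measured evidence bears on the result.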